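Amino in place of isobutyl on the carbonyl carbon

This account rests on a few compounds, and the source may have more. Where it says the series, first, only, none or still open, it means among the compounds named here.

In an assay on membranes from HeLa cells for displacement of a labelled ligand from adenosine receptor A3 (Homo sapiens), read by scintillation counting, with a stated time of 180 min, tested at 1 uM (on this read-out higher numbers stand for more inhibition at the one concentration tested (going by the name of the read-out) and lower numbers for less inhibition), compound 3 `CC1=C(C(=O)CC(C)C)C(c2ccoc2)NC(=O)N1` gives 18%, the largest of the three numbers, though compound 2 `CCCOC(=O)C1=C(C)NC(=O)NC1c1ccoc1` lies within the scatter of it at 11%; only compound 1 `COC(=O)C1=C(C)NC(=O)NC1c1ccoc1`, at 2%, stands clearly apart. Compound 4 `CC1=C(C(N)=O)C(c2ccoc2)NC(=O)N1` carries the change (amino in place of isobutyl on a carbonyl carbon). Among the compounds with values here, two measured steps bear on it, both with isobutyl entering: a number 16 percentage points higher from compound 1 to compound 3 (beyond the scatter) and a number 7 percentage points higher from compound 2 to compound 3 (within the scatter). In compound 4 isobutyl leaves and a smaller amino group enters, so a downward step back toward the level of compound 1 is expected in this assay, modest in size. For compound 4 the estimated value is 5%, with a range from -8% to 18%. The step that this estimate implies is a number 13 percentage points lower from compound 3 to compound 4 (beyond the scatter).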

Compound 4, a percentage reported as inhibition, at one concentration (the size of the read-out at that concentration, not a potency): 2%
Compound 4: the middle estimate sits 3 percentage points above what was measured; the range from low to high includes it.
By their numbers in this assay, from the lowest: compounds 1, 4, 2 and 3 (each within the scatter of the next, the first and the last beyond it).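

In this assay, the replacements on the carbonyl carbon do not all give the same number: amino in place of isobutyl removes the gain seen with isobutyl (a number 16 percentage points lower from compound 3 to compound 4 (beyond the scatter)). Amino does not separate from propoxy (a number 9 percentage points lower from compound 2 to compound 4 (within the scatter)) or from methoxy (no change at the digits printed from compound 1 to compound 4 (within the scatter)), so only isobutyl stands clearly above compound 1 and compound 4. Nothing available explains the drop.

As far as these compounds go, whether a dimethylamino group or a longer carbon chain on this carbonyl carbon would match or exceed isobutyl remains open.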